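This account rests on a few compounds, and the source may have more. Where it says the series, first, only, none or still open, it means among the compounds named here.

Working notes on the series. Compound 1 `C=C1[C@H](O)[C@]23C[C@@]1(O)CC[C@H]2[C@@]12C=C[C@H](O)[C@](C)(C(=O)O1)[C@H]2[C@@H]3C(=O)OC` and compound 2 `C=C1[C@H](O)[C@]23C[C@@]1(O)CC[C@H]2[C@@]12C=C[C@H](O)[C@](C)(C(=O)O1)[C@H]2[C@@H]3C(=O)OCc1ccccc1` share one core; compound 3 `C=C1C(=O)[C@]23C[C@@]1(Cl)CC[C@H]2[C@@]12C=CC(=O)[C@](C)(C(=O)O1)[C@H]2[C@@H]3C(=O)OC` and the not yet measured compound 4 `C=C1C(=O)[C@]23C[C@@]1(Cl)CC[C@H]2[C@@]12C=CC(=O)[C@](C)(C(=O)O1)[C@H]2[C@@H]3C(=O)OCc1ccccc1` share another, and the difference between the two cores is not broken down here. In a functional assay on BIU87 cells (Homo sapiens) for cytotoxicity, read by MTT assay (on this read-out lower numbers stand for stronger inhibition and higher numbers for weaker inhibition), compound 1 gives only a limit, > 100 ug/mL. In this assay compound 2 likewise gives only a limit, > 100 ug/mL. In this assay, within the data shown here, compound 3 gives 1 ug/mL, the one number in the set.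

The change from compound 1 to compound 2 is phenyl in place of hydrogen on a saturated chain carbon bound to an oxygen next to a carbonyl group. Its step, a step that the two limits leave unreadable from compound 1 to compound 2, cannot be read because both ends sit at the limit of > 100 ug/mL in this assay, at which 2 of the 3 values shown sit. The change from compound 3 to compound 4 is phenyl in place of hydrogen on a saturated chain carbon bound to an oxygen next to a carbonyl group, the same change at the same place, so the earlier pair gives no size to carry over.

With no readable step for this change, the expectation for compound 4 rests on compound 3 alone, at 1 ug/mL, and the step of a 1.5-fold higher number from compound 3 to compound 4 (0.18 log units; within the scatter) is expected to stay small. Compound 4 is thus estimated at 1.5 ug/mL, with a range from 0.4 ug/mL to 6 ug/mL.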

Compound 4, half-maximal inhibitory concentration: 0.5 ug/mL
Compound 4: the middle estimate sits 3.0-fold (0.48 log units) above what was measured, and the stated range covers the measured number.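

In this assay, methoxycarbonyl to benzyloxycarbonyl on the core of compound 3 gives a 2.0-fold lower number from compound 3 to compound 4 (0.30 log units; within the scatter), so on this core the phenyl that enters leaves the read-out within the usual scatter of repeated measurements. This is one readable size for the change, on one core, and it does not show that the change behaves alike on both cores. The same change on the core of compound 1 cannot be read, because both ends are limits of the assay and not numbers: the limit of > 100 ug/mL in this assay, at which 2 of the 4 values shown sit.

Still open, on these data alone, is how other groups would read on the core of compound 3 in this assay, for example a carboxylic acid in place of the methoxycarbonyl, a longer chain such as butyl in place of the methyl, or an amine carried on the phenyl. Also open is which single part of the difference between the two cores goes with the values, since the compounds shown do not break that difference down.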